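A few compounds are considered here, and "the series" means these few. Any claim that something is new, unique, unknown or untested is made for them only; others in the source may bear on it.

Three measured compounds share one core and differ only in the group carried on one aromatic carbon. Compound 1 `Cc1cc(OC2CCCCC2)c(S(C)(=O)=O)cc1C(=O)N=C(N)N` gives 37 nM in a functional assay for inhibition of sodium/hydrogen exchanger (Oryctolagus cuniculus); on this read-out lower numbers stand for stronger inhibition and higher numbers for weaker inhibition. Compound 2 `Cc1cc(-n2ccnc2)c(S(C)(=O)=O)cc1C(=O)N=C(N)N` gives 23 nM in this assay, and compound 3 `Cc1cc(-n2cccn2)c(S(C)(=O)=O)cc1C(=O)N=C(N)N` gives 25 nM. Among these three numbers compound 3 stands second highest, yet every step between them is within the scatter: a 1.6-fold lower number from compound 1 to compound 2 (0.21 log units; within the scatter), a 1.5-fold lower number from compound 1 to compound 3 (0.17 log units; within the scatter), and a 1.1-fold higher number from compound 2 to compound 3 (0.04 log units; within the scatter). Compound 4 `Cc1cc(Nc2ccccc2)c(S(C)(=O)=O)cc1C(=O)N=C(N)N` has not yet been measured; it carries anilino in place of 1H-pyrazol-1-yl on an aromatic carbon. Each earlier exchange on this aromatic carbon moved the number only within the scatter, so no shift beyond the scatter is expected here either, and the expected step is a 1.2-fold higher number from compound 3 to compound 4 (0.08 log units; within the scatter). Compound 4 is estimated at 30 nM, with a range from 12 nM to 75 nM.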

Compound 4, half-maximal inhibitory concentration: 21 nM
The estimate for compound 4 lay 1.4-fold (0.15 log units) above the measured number; the range from low to high includes it.
By their numbers in this assay, from the lowest: compounds 4, 2, 3 and 1 (each within the scatter of the next).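

Anilino carries a hydrogen-bond donor and a six-membered aromatic ring of carbon only, unlike 1H-pyrazol-1-yl, yet the exchange stays within the scatter against 1H-pyrazol-1-yl (a 1.2-fold lower number from compound 3 to compound 4 (0.08 log units; within the scatter)), against 1H-imidazol-1-yl (a 1.1-fold lower number from compound 2 to compound 4 (0.04 log units; within the scatter)) and against cyclohexyloxy (a 1.8-fold lower number from compound 1 to compound 4 (0.25 log units; within the scatter)). This aromatic carbon has now taken a group joined through a ring-free nitrogen with no clear change in the number. No measurement here accounts for this result. Still open, as far as these compounds go, is whether a small amine, a carboxylic acid or a longer chain on this carbon would shift the number beyond the scatter.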